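From methyl to isopropyl on compound 1

A few compounds are considered here, and "the series" means these few. Any claim that something is new, unique, unknown or untested is made for them only; others in the source may bear on it.

Compound 1 `C/C(=N/c1ccnc2cc(Cl)ccc12)NC1CCN(Cc2ccccc2)CC1` has been tested in an ADME assay (liver) for metabolic stability, with Liver microsome (Homo sapiens) as the target, read by LC-MS, using microsomes, tested at 1 uM; a higher number here means that the compound lasts longer, a lower number that the compound disappears faster. There, compound 1 gives > 1 h, which is a limit of the assay and not a number. Compound 2 `C/C(=N/c1ccnc2cc(Cl)ccc12)NC1CCN(C(C)C)CC1` gives > 1 h in this assay, and this too is a limit. Together they make up all of the evidence so far, (the limit of > 1 h in this assay, at which 2 of the 2 values shown sit).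

Within the data shown here, compound 3 `CC(C)/C(=N/c1ccnc2cc(Cl)ccc12)NC1CCN(Cc2ccccc2)CC1` carries a different change from the one in compound 2: isopropyl in place of methyl on a carbon with a double bond to nitrogen. In words, it has isopropyl in place of methyl on a carbon with a double bond to nitrogen.

Among the measured compounds shown here, only one measured step is available, a step that the two limits leave unreadable from compound 1 to compound 2, which puts isopropyl in place of benzyl on an amine nitrogen in a ring. For the measured compounds named here, that step has no readable size and occurs at another place, so it gives little guidance, and no measured step covers the new change. The expectation therefore starts from compound 1, whose > 1 h is only a limit. The expected step, a step that the limit leaves unreadable from compound 1 to compound 3, is estimated to stay within the scatter, with no firm direction. For compound 3 the estimated half-life in this assay is 1.2 h, with an expected range from 0.5 h to 2.5 h.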

Compound 3, half-life: 0.417 h
Compound 3: middle estimate off by 2.9-fold (0.46 log units), on the high side; measured number outside the range, below it.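

In this assay, the group on the carbon with a double bond to nitrogen proves to be a place where a change can be read: isopropyl in place of methyl there gives an at least 2.3-fold lower number from compound 1 to compound 3 (0.37 log units; beyond the scatter). Among these compounds, this is the first step with a direction, and compound 3 is the first compound to give a number and not a limit of the assay. The earlier change, on the amine nitrogen in a ring, cannot be read, so the two places cannot be ranked against each other, and compound 1 and compound 2 stay unseparated: the limit of > 1 h in this assay, at which 2 of the 3 values shown sit.

The compounds shown hold only methyl and isopropyl on this carbon, which leaves open how an ethyl or a cyclopropyl there would fare in this assay, and whether the fall grows steadily along such a series or appears only with isopropyl. They also leave open whether isopropyl at this place lowers the half-life in the same way when the amine nitrogen in a ring carries isopropyl in place of benzyl, as it does in compound 2.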